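Hydroxy Removed, Methyl Added on the Aryl Imine

A few compounds are considered here, and "the series" means these few. Any claim that something is new, unique, unknown or untested is made for them only; others in the source may bear on it.

Compound 2 `CCCCCCCCCCCCCCNC(=O)[C@H](CO)/N=C/c1cccc(O)c1` carries a 3-hydroxyphenyl on a carbon with a double bond to nitrogen in the shared core. For the measured compounds named here, in a functional assay on cells (Homo sapiens) for cytotoxicity, read by MTT assay, with a stated time of 24 h (on this read-out lower numbers stand for stronger inhibition and higher numbers for weaker inhibition), compound 2 gives 32600 nM, the highest of the two numbers measured so far. Its nearest neighbour is compound 1 `CCCCCCCCCCCCCCNC(=O)[C@H](CO)/N=C/c1ccccc1`, which differs only by a hydrogen in place of the hydroxy on an aromatic carbon; in this assay compound 1 gives 7670 nM. Going by the values given here, the single measured step, a 4.3-fold higher number from compound 1 to compound 2 (0.63 log units; beyond the scatter), shows a modest but real rise in the number when the hydroxy is present.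

Compound 3 `CCCCCCCCCCCCCCNC(=O)[C@H](CO)/N=C/c1ccccc1C` changes the ring: 2-methylphenyl in place of 3-hydroxyphenyl on a carbon with a double bond to nitrogen. The hydroxy that accompanied the higher number of compound 2 is gone, and a methyl is present instead. Among the compounds with values here, this change is expected to undo the earlier rise because a 4.3-fold higher number from compound 1 to compound 2 (0.63 log units; beyond the scatter) is the only measured guide, while nothing measured speaks to the methyl. Compound 3 is therefore expected to return roughly to the level of compound 1, with a 4.3-fold lower number from compound 2 to compound 3 (0.64 log units; beyond the scatter). The estimate for compound 3 is 7500 nM, ranging from 3000 nM to 20000 nM.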

Compound 3, half-maximal inhibitory concentration: 87700 nM
Estimate against measurement, compound 3: 12-fold (1.07 log units) below; measured number above the stated range.
By their numbers in this assay, from the lowest: compound 1; then compound 2; then compound 3.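

In this assay, the methyl in place of hydrogen gives an 11-fold higher number from compound 1 to compound 3 (1.06 log units; beyond the scatter), a large step, so the ring of compound 1 does not tolerate only the hydroxy poorly: both substituted rings shown stand above the unsubstituted phenyl, and no compound shown goes against this. Taking out the 3-hydroxyphenyl for the 2-methylphenyl on the carbon with a double bond to nitrogen does not bring the number back down but gives a 2.7-fold higher number from compound 2 to compound 3 (0.43 log units; beyond the scatter), which shows that the higher numbers do not depend on the hydrogen-bond donor and acceptor of the hydroxy, as the 2-methylphenyl has neither. Nothing shown accounts for either step.

Because compound 2 and compound 3 differ in both the group and where it sits on the ring, their step cannot separate the two, and 3-methylphenyl or 2-hydroxyphenyl would be the rings that could. As far as these compounds go, it also remains open whether any group on this ring can bring the number below that of compound 1, for instance an amine, a carboxylic acid or a methoxy.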